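The compounds below may be only part of what the source reports. "The series", "measured", "known", "first", "only" and "open" are said of these compounds alone.

Measured compounds:
compound 1 `CC1(C)[C@@H]2CC[C@@]1(CS(=O)(=O)N1CCN(c3ccc(C(F)(F)F)cn3)C(c3ccccc3)C1)C(=O)C2`: > 31600 nM
compound 2 `CC1(C)[C@@H]2CC[C@@]1(CS(=O)(=O)N1CCN(c3ncc(C(F)(F)F)cc3Cl)CC1)C(=O)C2`: 398 nM
compound 3 `CC1(C)[C@@H]2CC[C@@]1(CS(=O)(=O)N1CCN(c3ccc(C(F)(F)F)cn3)CC1)C(N)C2`: 794 nM

In a functional assay on CHO-K1 cells for antagonist activity at C-X-C chemokine receptor type 3 (Homo sapiens), read by FLIPR and calcium flux (a higher number here means a weaker inhibitor, a lower number a stronger inhibitor), compound 3 gives 794 nM. Compound 2, at 398 nM, sits within the usual scatter of compound 3, so the two cannot be told apart. For compound 1 this assay reports only a limit, > 31600 nM (the limit of > 31600 nM in this assay, at which 1 of the 3 values shown sits), and no number.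

Compound 4 `CC1(C)[C@@H]2CC[C@@]1(CS(=O)(=O)N1CCN(c3ccc(C(F)(F)F)cn3)CC1)C(NS(C)(=O)=O)C2` differs from compound 3 in one place: methylsulfonyl in place of hydrogen on an amine nitrogen. Among the compounds with values here, no comparable step between measured compounds exists here, and the two numbers that stand give no lead for a change at this amine. The step from compound 3 to compound 4 is therefore expected to stay modest, a 1.3-fold higher number from compound 3 to compound 4 (0.10 log units; within the scatter), with either direction open. Compound 4 is estimated at 1000 nM, in the range 250 nM to 5000 nM.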

Compound 4, half-maximal inhibitory concentration: 631 nM
Estimate against measurement, compound 4: 1.6-fold (0.20 log units) above; the range from low to high includes it.
By their numbers in this assay, from the lowest: compounds 2, 4 and 3 (each within the scatter of the next). At a limit, above all of these: compound 1.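

In this assay, methylsulfonyl in place of hydrogen on this amine nitrogen gives two compounds that cannot be told apart (a 1.3-fold lower number from compound 3 to compound 4 (0.10 log units; within the scatter)). The position therefore accepts a group of this size on the nitrogen, and in this pair the amine hydrogen is not required for the activity. Nothing in the evidence at hand explains this result. As far as these compounds go, whether an acetyl group or a longer chain on the sulfonyl would read the same stays open. So does whether any group on this nitrogen can move the number beyond the scatter.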